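Swapping methoxy for cyano on a benzyl group

The compounds below may be only part of what the source reports. "The series", "measured", "known", "first", "only" and "open" are said of these compounds alone.

Three compounds measured in a functional assay on the whole organism (B cells) with Mus musculus as the target (a higher number here means a larger maximal response, a lower number a smaller maximal response), share one core and differ in the groups attached to it. Compound 1 `C=CCn1c(=O)n(C2CCC(CO)C2)c2nc(N)nc(O)c21` gives 26% in this assay. Compound 2 `C=CCn1c(=O)n(CCC(CCOCc2ccccc2)CCOCc2ccccc2)c2nc(N)nc(O)c21` reaches 68% in this assay. Compound 3 `COc1ccc(Cn2c(=O)n(C3OC(CO)[C@@H](O)[C@H]3O)c3nc(N)nc(O)c32)cc1` gives 44% in this assay, which places it second highest of the three numbers: it lies above compound 1 by a margin beyond the usual scatter and below compound 2, again by more than the scatter.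

The next compound, compound 4 `N#Cc1ccc(Cn2c(=O)n(C3OC(CO)[C@@H](O)[C@H]3O)c3nc(N)nc(O)c32)cc1`, has not yet been measured. It differs from compound 3 in one place only: cyano in place of methoxy on an aromatic carbon. Among the measured compounds shown here, no pair among the measured compounds shows this particular change, so no measured step tells how the maximal response moves with it. Without such a comparison, the expected step from compound 3 to compound 4 is small, not beyond the scatter in either direction, and is estimated as a number 1 percentage points higher from compound 3 to compound 4 (within the scatter). Compound 4 is therefore expected to give about 45% in this assay, within a range from 25% to 65%.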

Compound 4, largest response reached (reported as maximal response), in percent of the reference or control that the assay uses: 50%
Compound 4: middle estimate off by 5 percentage points, on the low side; the measured number falls inside the stated range.
By their numbers in this assay, from the lowest: compound 1; then compounds 3 and 4 (each within the scatter of the next); then compound 2.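

In this assay, among the compounds shown here, the swap of methoxy for cyano gives a number 6 percentage points higher from compound 3 to compound 4 (within the scatter) and is the first direct reading of this change on the shared core. At this place, an aromatic carbon para to a large group, the 4-methoxybenzyl and 4-cyanobenzyl compounds cannot be told apart by their maximal response, so this pair gives no sign that the choice between these two groups matters here. Nothing measured here points to what lies behind this result.

On these data alone, this is a single pair, so it remains open whether the change would read the same alongside the other groups carried by compound 1 and compound 2. Also open, as far as these compounds go, is how an amine, a carboxylic acid or a longer chain on this same aromatic carbon would compare with methoxy and cyano.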